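A few compounds are considered here, and "the series" means these few. Any claim that something is new, unique, unknown or untested is made for them only; others in the source may bear on it.

Of the compounds shown here, three built on one shared core have been tested in a functional assay on the whole organism for inhibition, with Rattus norvegicus as the target, in the maximal electroshock model, at a dose of 25 mg/kg by the intraperitoneal route; on this read-out higher numbers stand for more inhibition at the one dose given (going by the name of the read-out) and lower numbers for less inhibition. Compound 1 `c1ccc(Cn2cnc3c(Nc4ccccc4)ncnc32)cc1` gives 0%. Within the data shown here, compound 2 `Oc1ncnc2c1ncn2Cc1ccccc1` gives 17%, and the step of a number 17 percentage points higher from compound 1 to compound 2 (beyond the scatter) is the only change measured at a single place. Compound 3 `CN(C)c1ncnc2c1ncn2Cc1ccc(Cl)cc1` gives 0%, level with compound 1 at the digits shown, the two together the lowest of the three numbers, while compound 2 stands higher by an amount beyond the scatter.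

Compound 4 `CN(C)c1ncnc2c1ncn2Cc1ccc(C#N)cc1` differs from compound 3 by cyano in place of chloro on an aromatic carbon. Among the measured compounds shown here, no measured step bears on this change: the one step known, a number 17 percentage points higher from compound 1 to compound 2 (beyond the scatter), concerns a group on an aromatic carbon of the core, not the ring that carries the chloro, and compound 3 itself shows no inhibition from which a change could be seen downward. The expectation is therefore a step of none beyond the scatter. Compound 4 is expected to give 3%, in the range 0% to 15%. This means an expected step of a number 3 percentage points higher from compound 3 to compound 4 (within the scatter).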

Compound 4, a percentage reported as inhibition, in the whole organism at one dose (the size of the read-out at that dose, not a potency): 0%
The estimate for compound 4 lay 3 percentage points above the measured number; measured number inside the range.
By their numbers in this assay, from the lowest: compounds 1, 3 and 4 (each within the scatter of the next); then compound 2.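

Among these compounds, replacing chloro with cyano on the six-membered aromatic ring of carbon only gives the first measured step at this position: in this assay, there is no change at the digits printed from compound 3 to compound 4 (within the scatter). With the dimethylamino group kept on the core, neither chloro nor cyano at this place brings any measurable inhibition at the one dose given, and with both numbers at the bottom of the scale, a change that lowers inhibition could not show. No measurement at hand offers an explanation for this result.

Still open, from the compounds shown here alone, is whether any group at this place can raise the number, and a methoxy group, an amine or a carboxylic acid would test that. Also open, going by these compounds, is whether chloro and cyano would match each other on a core carrying hydroxy instead of dimethylamino.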